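Methoxy additions: from compound 2 to compound 3

A few compounds are considered here, and "the series" means these few. Any claim that something is new, unique, unknown or untested is made for them only; others in the source may bear on it.

- compound 1 `Oc1cccc2[nH]c(-c3ccc(-c4ccc(-c5ccccc5)cc4)cc3)nc12`: 4010 nM
- compound 2 `COc1ccc(-c2ccc(-c3ccc(-c4nc5c(O)cccc5[nH]4)cc3)cc2)cc1`: 4900 nM

In a functional assay on KB cells (Homo sapiens) for inhibition, read by sulforhodamine B assay (on this read-out lower numbers stand for stronger inhibition of growth and higher numbers for weaker inhibition of growth), compound 2 gives 4900 nM, within the scatter of compound 1. Next comes compound 3 `COc1ccc(-c2ccc(-c3ccc(-c4nc5c(O)cccc5[nH]4)cc3)cc2)cc1OC`, with methoxy in place of hydrogen on an aromatic carbon: 4-methoxyphenyl to 3,4-dimethoxyphenyl, the new methoxy ortho to a methoxy group. Among the compounds with values here, the one measured step bearing on this is the same kind of replacement, a 1.2-fold higher number from compound 1 to compound 2 (0.09 log units; within the scatter). With a precedent of that size, no shift beyond the scatter is expected in this assay, in either direction. The expected change is a 1.0-fold higher number from compound 2 to compound 3 (0.01 log units; within the scatter). For compound 3 the estimated value is 5000 nM, with an expected range of 2200 nM to 11000 nM.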

Compound 3, concentration for 50% growth inhibition: 2710 nM
For compound 3 the middle estimate is 1.8-fold (0.27 log units) above the measured one; the measured number falls inside the stated range.
By their numbers in this assay, from the lowest: compounds 3, 1 and 2 (each within the scatter of the next).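

The change from 4-methoxyphenyl to 3,4-dimethoxyphenyl (a 1.8-fold lower number from compound 2 to compound 3 (0.26 log units; within the scatter)) shows that in this assay a methoxy ortho to a methoxy group is accommodated without a shift beyond the scatter. The whole change of 3,4-dimethoxyphenyl in place of phenyl (a 1.5-fold lower number from compound 1 to compound 3 (0.17 log units; within the scatter)) also stays within the scatter, so the two methoxy groups together leave the number where the unsubstituted phenyl had it. No evidence is available that bears on these results.

Still open, as far as these compounds go, is whether an amine or a carboxylic acid on this ring would move the number beyond the scatter. Methoxy alone does not settle how far this position tolerates other groups.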